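From 3,4-dichlorobenzyl to 2-chloro-4-fluorobenzyl

The source may report more compounds than this note shows. Statements on the series, on what has been measured and on what is new or still open speak of the compounds shown alone.

In a functional assay on HL-60 cells (Homo sapiens) for antiproliferative activity, with a stated time of 72 h (on this read-out lower numbers stand for stronger inhibition and higher numbers for weaker inhibition), compound 1 `OC[C@H]1O[C@@H](n2cnc3c(NCc4ccc(Cl)cc4)ncnc32)[C@H](O)[C@@H]1O` gives 1700 nM, compound 2 `OC[C@H]1O[C@@H](n2cnc3c(NCc4ccc(Cl)cc4Cl)ncnc32)[C@H](O)[C@@H]1O` gives 96300 nM and compound 3 `OC[C@H]1O[C@@H](n2cnc3c(NCc4ccc(Cl)c(Cl)c4)ncnc32)[C@H](O)[C@@H]1O` gives 2000 nM. Compound 3 therefore sits level with compound 1, as shown by a 1.2-fold higher number from compound 1 to compound 3 (0.07 log units; within the scatter), and far from compound 2, as shown by a 48-fold lower number from compound 2 to compound 3 (1.68 log units; beyond the scatter). Compound 4 `OC[C@H]1O[C@@H](n2cnc3c(NCc4ccc(F)cc4Cl)ncnc32)[C@H](O)[C@@H]1O`, not yet measured, carries 2-chloro-4-fluorophenyl in place of 3,4-dichlorophenyl on a saturated chain carbon bound to a nitrogen on an aromatic ring. The best guide is compound 2, whose 2,4-dichlorophenyl is the measured group most like the entering one, and a 57-fold higher number from compound 1 to compound 2 (1.75 log units; beyond the scatter) shows how much that group separates it from compound 1. Going by the values given here, no measured compound carries a fluoro group, so the comparison is uncertain. Among the compounds with values here, a large move towards a higher number is expected in this assay, probably somewhat smaller than the one seen for compound 2. The estimated step is a 15-fold higher number from compound 3 to compound 4 (1.18 log units; beyond the scatter). Compound 4 is estimated at 30000 nM, with an expected range of 6000 nM to 100000 nM.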

Compound 4, half-maximal inhibitory concentration: 9000 nM
The estimate for compound 4 lay 3.3-fold (0.52 log units) above the measured number; low and high end bracket the measured number.
By their numbers in this assay, from the lowest: compounds 1 and 3 (each within the scatter of the next); then compound 4; then compound 2.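

Changing only the group on the aromatic carbon, fluoro in place of chloro, gives an 11-fold lower number from compound 2 to compound 4 (1.03 log units; beyond the scatter) in this assay, so the very high number seen with 2,4-dichlorophenyl does not carry over in full to 2-chloro-4-fluorophenyl. The recovery is only partial: 2-chloro-4-fluorophenyl still gives a 4.5-fold higher number from compound 3 to compound 4 (0.65 log units; beyond the scatter) and a 5.3-fold higher number from compound 1 to compound 4 (0.72 log units; beyond the scatter), both modest steps, so at this place on a saturated chain carbon bound to a nitrogen on an aromatic ring it stays behind 3,4-dichlorophenyl and 4-chlorophenyl. Nothing available explains why fluoro and chloro differ so much here.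

The share of the chloro and of the fluoro in these steps stays open, since the compounds shown include neither 2-chlorophenyl nor 4-fluorophenyl. Also open, from the compounds shown here alone, is how a methoxy or trifluoromethyl group would read in this place.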